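Swapping dimethoxyphenyl for chlorophenyl on the pyrimidinone arm

The source may hold more compounds than are shown below. What is called first, only, known or untested is meant among the compounds shown, and "the series" means these compounds.

Of the compounds shown here, three share one core and have been tested in a functional assay on U-87MG ATCC cells for antiproliferative activity against U-87 MG (Homo sapiens), read by MTT assay, with a stated time of 48 h, tested at 50 uM; on this read-out lower numbers stand for a stronger effect and higher numbers for a weaker effect at the one concentration tested. Compound 1 `COc1ccc(-c2nc(C)c(C(=O)CSc3nc(-c4ccc(OC)cc4)c(C#N)c(=O)[nH]3)s2)cc1` gives 32.6%. Compound 2 `COc1ccc(-c2nc(C)c(C(=O)CSc3nc(-c4ccc(OC)c(OC)c4)c(C#N)c(=O)[nH]3)s2)cc1` gives 22.2%, the lowest and therefore strongest number of the three, beyond the scatter from both others. Compound 3 `COc1ccc(-c2nc(SCC(=O)c3sc(-c4ccc(Cl)cc4)nc3C)[nH]c(=O)c2C#N)cc1OC` gives 59.8%. Two single-point steps connect them: a number 10.4 percentage points lower from compound 1 to compound 2 (beyond the scatter), and a number 37.6 percentage points higher from compound 2 to compound 3 (beyond the scatter).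

Compound 4 `COc1ccc(-c2nc(C)c(C(=O)CSc3nc(-c4cccc(Cl)c4)c(C#N)c(=O)[nH]3)s2)cc1` has not yet been tested in this assay. Compared with compound 2 the change is 3-chlorophenyl in place of 3,4-dimethoxyphenyl on an aromatic carbon. Both measured steps bear on it. The first step shows that losing a methoxy costs a modest amount, and the second shows that chloro in place of methoxy, though on the other aryl ring, costs a large amount. Taken together, compound 4 is expected to give a weaker read-out than compound 2, and the expected step is a number 27.8 percentage points higher from compound 2 to compound 4 (beyond the scatter). The estimate for compound 4 in this assay is 50%, with a range from 30% to 70%.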

Compound 4, a percentage reported as activity, at one concentration (the size of the read-out at that concentration, not a potency): 83.4%
Beside the measured number, compound 4's estimate is 33.4 percentage points below it, outside the stated range (above it).
By their numbers in this assay, from the lowest: compound 2; then compound 1; then compound 3; then compound 4.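

In this assay, the step to 3-chlorophenyl at this position is large whichever methoxy-bearing aryl group it replaces: it gives a number 61.2 percentage points higher from compound 2 to compound 4 (beyond the scatter) and also a number 50.8 percentage points higher from compound 1 to compound 4 (beyond the scatter). Until now, this position had shown only the modest change of a number 10.4 percentage points lower from compound 1 to compound 2 (beyond the scatter) from adding a methoxy, whereas these steps show that the choice of aryl group here can move the read-out much further. No measurement shown explains why this swap weakens the read-out so strongly.

The 3-chlorophenyl group differs from the two methoxy-bearing groups both in what it carries and in where it carries it, so the effects of these two differences cannot be separated. Plain phenyl, 3-methoxyphenyl, 4-chlorophenyl, or an aryl group bearing a hydroxyl or an amine at this position remain open.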